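Extending the acid on the amide-bound ring

This account rests on a few compounds, and the source may have more. Where it says the series, first, only, none or still open, it means among the compounds named here.

Three related compounds share one core and differ only in the group carried on the amide-type nitrogen. Compound 1 `C=C(CC)C(=O)c1ccc(OCC(=O)NCCO)c(Cl)c1Cl` bears a 2-hydroxyethyl group there; in a functional assay on CLL cells (Homo sapiens) for cytotoxicity, read by MTT assay, with a stated time of 48 h (on this read-out lower numbers stand for an effect already at smaller amounts and higher numbers for an effect only at larger amounts of compound), compound 1 gives only a limit, > 25000 nM. Compound 2 `C=C(CC)C(=O)c1ccc(OCC(=O)Nc2ccc(C(=O)O)cc2)c(Cl)c1Cl` carries a 4-carboxyphenyl group, and in this assay compound 2 gives 5000 nM, the higher of the two plain numbers here. Compound 3 `C=C(CC)C(=O)c1ccc(OCC(=O)NO)c(Cl)c1Cl` carries hydroxy, and in this assay compound 3 gives 4500 nM; the gap a 1.1-fold lower number from compound 2 to compound 3 (0.05 log units; within the scatter) lies within the scatter, so the two cannot be told apart. Measured against the limit of compound 1, both replacements look helpful: an at least 5.0-fold lower number from compound 1 to compound 2 (0.69 log units; beyond the scatter) and an at least 5.5-fold lower number from compound 1 to compound 3 (0.74 log units; beyond the scatter).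

Compound 4 `C=C(CC)C(=O)c1ccc(OCC(=O)Nc2ccc(/C=C/C(=O)O)cc2)c(Cl)c1Cl` is not yet measured. Relative to compound 2 it shows (2-carboxyethenyl in place of carboxy on an aromatic carbon). Going by the values given here, none of the measured steps touches this position; all three change the group on the amide-type nitrogen, so they say little about lengthening the acid. The expectation is therefore for no step beyond the scatter, a 1.3-fold lower number from compound 2 to compound 4 (0.10 log units; within the scatter). Compound 4 is estimated at 4000 nM, between 1500 nM and 12000 nM.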

Compound 4, half-maximal effective concentration: 3000 nM
Compound 4: middle estimate off by 1.3-fold (0.12 log units), on the high side, within the range that was stated.
By their numbers in this assay, from the lowest: compounds 4, 3 and 2 (each within the scatter of the next). At a limit, above all of these: compound 1.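

The first change made on the aromatic ring itself, on the carbon para to a large group, gives a 1.7-fold lower number from compound 2 to compound 4 (0.22 log units; within the scatter) in this assay. The earlier steps shown here all altered the group on the amide-type nitrogen, whereas this one shows that compounds 2 and 4 cannot be told apart when carboxy gives way to the larger 2-carboxyethenyl, which keeps the carboxylic acid but adds a double bond outside the aromatic ring. Nothing measured here bears on how this change acts in the cells.

From the compounds shown here alone, it remains open what a saturated chain, such as 2-carboxyethyl, would do on this carbon. Also open, going by these compounds, is whether the carboxylic acid matters at all, which a methyl ester or an amine in its place would begin to test.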